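This account rests on a few compounds, and the source may have more. Where it says the series, first, only, none or still open, it means among the compounds named here.

Working notes on the series. The shared core of compound 1 `CCC(C)(C)Cc1c[nH]c(CCc2ccc(-c3ccncc3)cc2)n1` carries a pyridin-4-yl group; in a functional assay on HEK293 cells for agonist activity at Bombesin receptor subtype-3 (Homo sapiens), read by luminescence and calcium flux, with a stated time of 10 min (on this read-out lower numbers stand for an effect already at smaller amounts and higher numbers for an effect only at larger amounts of compound), compound 1 gives 305 nM. Compound 2 `CCC(C)(C)Cc1c[nH]c(CCc2ccc(N3CCCCC3)cc2)n1` differs only in that a piperidin-1-yl sits in place of the pyridin-4-yl on that aromatic carbon; in this assay compound 2 gives 171 nM. The step of a 1.8-fold lower number from compound 1 to compound 2 (0.25 log units; within the scatter) is within the scatter, so the two values cannot be ordered. For the measured compounds named here, compound 2 stands at the lower of the two numbers measured so far, with compound 1 as its nearest neighbour.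

Compound 3 `CCC(C)(C)Cc1c[nH]c(CCc2ccc(-c3ccns3)cc2)n1` is not yet measured. Its change from compound 2 is 1,2-thiazol-5-yl in place of piperidin-1-yl on an aromatic carbon. Going by the values given here, the only measured step that bears on this position is a 1.8-fold lower number from compound 1 to compound 2 (0.25 log units; within the scatter), where a six-membered aromatic ring with one hetero atom was replaced by the piperidin-1-yl; it stayed within the scatter. The entering 1,2-thiazol-5-yl is again an aromatic ring, which puts compound 3 nearer to compound 1 than to compound 2 in this respect. The step in this assay from compound 2 to compound 3 is therefore expected to be small, a 1.5-fold higher number from compound 2 to compound 3 (0.16 log units; within the scatter), not beyond the scatter. For compound 3 in this assay the estimate is 250 nM, with a range from 110 nM to 560 nM.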

Compound 3, half-maximal effective concentration: 63 nM
Estimate against measurement, compound 3: 4.0-fold (0.60 log units) above; measured number outside the range, below it.
By their numbers in this assay, from the lowest: compound 3; then compounds 2 and 1 (each within the scatter of the next).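

In this assay this position, on an aromatic carbon para to a large group, now gives steps beyond the scatter: a 2.7-fold lower number from compound 2 to compound 3 (0.43 log units; beyond the scatter) for 1,2-thiazol-5-yl in place of piperidin-1-yl, and a 4.8-fold lower number from compound 1 to compound 3 (0.68 log units; beyond the scatter) for 1,2-thiazol-5-yl in place of pyridin-4-yl. The earlier pair could not be ordered, so the position had shown no response to the change of ring until the five-membered aromatic ring entered. Pyridin-4-yl and 1,2-thiazol-5-yl are both aromatic yet stand apart beyond the scatter, so an aromatic ring at this place does not by itself fix the number, and compound 3 stands lowest of the three. No supporting data bear on what lies behind these steps.

The compounds shown leave open whether the lower number goes with the five-membered ring or with its sulfur, a question that a thiophen-2-yl or a 1,3-thiazol-2-yl at this place would address. Also open, as far as these compounds go, is whether the step holds when the alkyl chain on the shared core is replaced, for example by a shorter chain or a cyclohexylmethyl group.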